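Taking the nitro group off compound 3

The compounds below may be only part of what the source reports. "The series", "measured", "known", "first", "only" and "open" are said of these compounds alone.

Measured in a functional assay on MCF7 cells (Homo sapiens) for antiproliferative activity, read by MTT assay, with a stated time of 48 h; on this read-out lower numbers stand for stronger inhibition and higher numbers for weaker inhibition:
- compound 1 `COc1ccc2nc(NC(c3cn(-c4ccccc4)nc3-c3ccc(Cl)cc3)c3c(O)ccc4ccccc34)sc2c1`: 23700 nM
- compound 2 `COc1ccc2nc(NC(c3cn(-c4ccccc4)nc3-c3ccc([N+](=O)[O-])cc3)c3c(O)ccc4ccccc34)sc2c1`: 13300 nM
- compound 3 `COc1ccc2nc(NC(c3cn(-c4ccccc4)nc3-c3cccc([N+](=O)[O-])c3)c3c(O)ccc4ccccc34)sc2c1`: 26800 nM

Compound 3 has no clear rank among these three compounds. The numbers show a 1.1-fold higher number from compound 1 to compound 3 (0.05 log units; within the scatter) and a 2.0-fold higher number from compound 2 to compound 3 (0.30 log units; within the scatter), and both steps lie within the scatter of repeated measurements. The next compound, compound 4 `COc1ccc2nc(NC(c3cn(-c4ccccc4)nc3-c3ccccc3)c3c(O)ccc4ccccc34)sc2c1`, keeps the shared core and changes one thing: hydrogen in place of nitro on an aromatic carbon. In words, this is hydrogen in place of nitro on an aromatic carbon, so 3-nitrophenyl becomes phenyl.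

The closest evidence comes from the steps already measured. Alongside the two above, the numbers show a 1.8-fold lower number from compound 1 to compound 2 (0.25 log units; within the scatter), also within the scatter. Across these three compounds, then, exchanging the group or shifting the nitro has not moved the number beyond the scatter. None of these steps removes a group and leaves only hydrogen, however, so they are an imperfect guide and the range should stay wide. The expected result is a 1.2-fold lower number from compound 3 to compound 4 (0.09 log units; within the scatter), which is an estimated change no larger than the scatter and with no firm direction. In this assay, the estimate for compound 4 is 22000 nM, with an expected range from 10000 nM to 50000 nM.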

Compound 4, half-maximal inhibitory concentration: 40800 nM
Beside the measured number, compound 4's estimate is 1.9-fold (0.27 log units) below it; low and high end bracket the measured number.
By their numbers in this assay, from the lowest: compounds 2, 1, 3 and 4 (each within the scatter of the next, the first and the last beyond it).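

In this assay, among these compounds, this is the first comparison that leaves only hydrogen at this place on the ring, and for two of the three starting points the loss cannot be told apart from no change: hydrogen in place of nitro gives a 1.5-fold higher number from compound 3 to compound 4 (0.18 log units; within the scatter), and hydrogen in place of chloro gives a 1.7-fold higher number from compound 1 to compound 4 (0.24 log units; within the scatter). The same exchange of nitro for hydrogen starting from the other nitro compound gives a 3.1-fold higher number from compound 2 to compound 4 (0.49 log units; beyond the scatter), a modest step and the only one here that clears the scatter, so a nitro group on this ring may count for something in compound 2 even though the evidence for it is a single pair. No measurement among the data shown accounts for why the two nitro compounds read differently when the nitro group is removed.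

From the compounds shown here alone, whether an amine or a carboxylic acid at this place would move the number further than nitro, chloro or hydrogen remains open, as does whether that one modest step would hold up on repeated measurement. The rest of the shared core is the same in all four compounds, so these numbers say nothing about changes elsewhere in it.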